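Compound 2 to compound 4: removing the benzylic arm

The source may hold more compounds than are shown below. What is called first, only, known or untested is meant among the compounds shown, and "the series" means these compounds.

Compound 1 `Cc1ccc2c(NCc3ccc(NC(=O)C4CCN(Cc5ccccc5)CC4)cc3)nc(N3CCC3)nc2c1`, compound 2 `Cc1ccc(CN2CCC(C(=O)Nc3ccc(CNc4nc(N(C)C)nc5cc(C)ccc45)cc3)CC2)cc1` and compound 3 `Cc1ccc2c(NCc3ccc(NC(=O)C4CCN(Cc5ccccc5)CC4)cc3)nc(N(C)CCN(C)C)nc2c1` share one core and have each been tested in a functional assay on SV5A8 cells (Homo sapiens) for cytotoxicity; a higher number here means a weaker inhibitor, a lower number a stronger inhibitor. In this assay compound 1 gives only a limit, > 8500 nM. In this assay compound 2 likewise gives only a limit, > 4150 nM. In this assay compound 3 also gives only a limit, > 8830 nM. Compound 2 thus stands at a limit, (the limit of > 4150 nM in this assay, at which 1 of the 3 values shown sits). The other two values are likewise limits, the limit of > 8500 nM in this assay, at which 1 of the 3 values shown sits, and (the limit of > 8830 nM in this assay, at which 1 of the 3 values shown sits). Within the data shown here, the only step between compounds that differ in one place, a step that the two limits leave unreadable from compound 1 to compound 3, cannot be read for size, since both ends are limits. Compound 4 `Cc1ccc2c(NCc3ccc(NC(=O)C4CCN(C)CC4)cc3)nc(N(C)C)nc2c1` differs from compound 2 by hydrogen in place of 4-methylphenyl on a saturated chain carbon bound to an amine nitrogen in a ring; cut one bond further out, this reads 4-methylbenzyl to methyl. Among the measured compounds shown here, no measured step touches this place, so nothing beyond the scatter is expected. The expected change is a step that the limit leaves unreadable from compound 2 to compound 4. For compound 4 in this assay the estimated value is 8000 nM, within 2000 nM to 30000 nM, most probably reported once more as a limit.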

Compound 4, half-maximal inhibitory concentration: > 17300 nM
Compound 4: only a limit was reported; the forecaster's own chance of this, stated with the estimate: 80%; middle value at least 2.1-fold (0.33 log units) from the limit.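

Compound 2 and compound 4 both stand at limits in this assay, and the step between them cannot be read for size. The compounds shown leave open whether 4-methylbenzyl to methyl changes the read-out at all, and where any of the four compounds reaches half-maximal inhibition.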